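Adding a Fluorine to a Urea Series Measured Only as Limits

This account rests on a few compounds, and the source may have more. Where it says the series, first, only, none or still open, it means among the compounds named here.

Three ureas share one core and differ only on the phenyl ring. Compound 1 `COc1ccccc1NC(=O)Nc1nc2ccc(F)cc2s1` carries a methoxy group, compound 2 `COc1ccc(NC(=O)Nc2nc3ccc(F)cc3s2)cc1` carries a methoxy group as well, and compound 3 `O=C(Nc1ccccc1)Nc1nc2ccc(F)cc2s1` carries none. All three were tested in a functional assay on MDA-MB-231 cells (Homo sapiens) for antiproliferative activity, read by sulforhodamine B assay; on this read-out higher numbers stand for weaker inhibition of growth and lower numbers for stronger inhibition of growth. In this assay compound 1 gives > 10 ug/mL, which is a limit of the assay rather than a number. In this assay compound 2 gives > 10 ug/mL, again a limit. In this assay compound 3 gives > 10 ug/mL, also a limit. Compound 3 therefore stands nowhere distinct among the numbers shown: the limit of > 10 ug/mL in this assay, at which 3 of the 3 values shown sit, so none of the three can be placed above or below the others. The step that the two limits leave unreadable from compound 1 to compound 3 and the step that the two limits leave unreadable from compound 2 to compound 3 both run between limits and cannot be read. Compound 4 `O=C(Nc1nc2ccc(F)cc2s1)Nc1ccccc1F` differs from compound 3 by fluoro in place of hydrogen on an aromatic carbon. Among the compounds with values here, the only measured steps that touch the phenyl ring are those from compounds 1 and 2, and neither has a readable size, so they give no direction for this change in this assay. No step beyond the scatter can be expected on that footing. Compound 4 is expected to give about 15 ug/mL in this assay, within a range from 5 ug/mL to 50 ug/mL, and most likely it too is reported as a limit. The step this estimate implies is a step that the limit leaves unreadable from compound 3 to compound 4, an expectation of no change beyond the scatter.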

Compound 4, concentration for 50% growth inhibition: > 10 ug/mL
Compound 4: a limit, no number; the forecaster's own chance of this, stated with the estimate: 75%; the middle value does not contradict the limit.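

Compound 4, like compound 3 and compound 1, gives a limit rather than a number in this assay, so no step among these compounds can be read: the limit of > 10 ug/mL in this assay, at which 4 of the 4 values shown sit.

The compounds shown leave open how hydrogen, methoxy and fluoro on the phenyl ring compare, and whether any of them gives a readable value in this assay.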